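Thiazole to isoxazole on the amide nitrogen

This account rests on a few compounds, and the source may have more. Where it says the series, first, only, none or still open, it means among the compounds named here.

Measured in a functional assay on HOP-62 cells (Homo sapiens) for cytotoxicity, read by sulforhodamine B assay, with a stated time of 48 h; a higher number here means a weaker inhibitor of growth, a lower number a stronger inhibitor of growth:
Compound 1 `Cc1c(NC(=O)COc2ccc(/C=C3\SC(=O)NC3=O)cc2)c(=O)n(-c2ccccc2)n1C`: 186 nM
Compound 2 `Cc1cnc(NC(=O)COc2ccc(/C=C3\SC(=O)NC3=O)cc2)s1`: 30900 nM
Compound 3 `O=C1NC(=O)/C(=C\c2ccc(OCC(=O)N3C(=O)c4ccccc4S3(=O)=O)cc2)S1`: the reported value < 100000 nM is a limit of the assay, not a number.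

Of the two compounds with a number, compound 2 stands highest; compound 1 sits far below it, well beyond the scatter. Compound 4 `Cc1cc(NC(=O)COc2ccc(/C=C3\SC(=O)NC3=O)cc2)no1` differs from compound 2 in one place: 5-methyl-1,2-oxazol-3-yl in place of 5-methyl-1,3-thiazol-2-yl on an amide-type nitrogen. Within the data shown here, no measured pair shows this change, so its size is unknown; the two groups match in ring size, hetero-atom count and acceptor count, which gives no ground for a move beyond the scatter in either direction. Compound 4 is therefore expected to give about 30000 nM in this assay, between 8000 nM and 100000 nM. The expected step of a 1.0-fold lower number from compound 2 to compound 4 (0.01 log units; within the scatter) is none beyond the scatter.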

Compound 4, concentration for 50% growth inhibition: < 100000 nM
Compound 4: only a limit was reported; the forecaster's own chance of this, stated with the estimate: 25%; the middle value lies beyond the limit too.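

Compound 4 gives only a limit (< 100000 nM), so no step from compound 2 to compound 4 can be read, the result sitting at the assay's limit: the limit of < 100000 nM in this assay, at which 2 of the 4 values shown sit.

The compounds shown leave open whether 5-methyl-1,2-oxazol-3-yl and 5-methyl-1,3-thiazol-2-yl on the amide-type nitrogen differ at all.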